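Compound 4: a ring swap with no number to start from

The source may report more compounds than this note shows. Statements on the series, on what has been measured and on what is new or still open speak of the compounds shown alone.

Measured in a functional assay on HL-60 cells (Homo sapiens) for antiproliferative activity, with a stated time of 72 h; a lower number here means a stronger inhibitor, a higher number a weaker inhibitor:
- compound 1 `OC[C@H]1O[C@@H](n2cnc3c(NCc4ccc(Cl)c(Cl)c4)ncnc32)[C@H](O)[C@@H]1O`: 2000 nM
- compound 2 `COc1cccc(CNc2ncnc3c2ncn3[C@@H]2O[C@H](CO)[C@@H](O)[C@H]2O)c1OC`: > 166000 nM, a limit and not a number
- compound 3 `OC[C@H]1O[C@@H](n2cnc3c(NCc4cc(O)cc(O)c4)ncnc32)[C@H](O)[C@@H]1O`: "not determined" (no result reported)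

Compound 3 has no number to start from, since its entry reads "not determined" (no result reported). Compound 4 `Cc1ccc(O)c(CNc2ncnc3c2ncn3[C@@H]2O[C@H](CO)[C@@H](O)[C@H]2O)c1` differs from it by 2-hydroxy-5-methylphenyl in place of 3,5-dihydroxyphenyl on a saturated chain carbon bound to a nitrogen on an aromatic ring, with 2-hydroxy-5-methylphenyl in place of 3,5-dihydroxyphenyl. Within the data shown here, the one measured change at this place gave an at least 83-fold higher number from compound 1 to compound 2 (1.91 log units; beyond the scatter), a large step. For compound 2 that result is a limit, (the limit of > 166000 nM in this assay, at which 1 of the 3 values shown sits). A large step is therefore possible in this assay, but with no value for compound 3, no direction can be expected. Compound 4 is estimated at 25000 nM, with an expected range from 3000 nM to 166000 nM.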

Compound 4, half-maximal inhibitory concentration: 15000 nM
Beside the measured number, compound 4's estimate is 1.7-fold (0.22 log units) above it; measured number inside the range.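

In this assay, the place on a saturated chain carbon bound to a nitrogen on an aromatic ring now shows an intermediate result: 2-hydroxy-5-methylphenyl gives an at least 11-fold lower number from compound 2 to compound 4 (1.04 log units; beyond the scatter), but still a 7.5-fold higher number from compound 1 to compound 4 (0.88 log units; beyond the scatter). The entry for compound 2 is a limit and not a number: the limit of > 166000 nM in this assay, at which 1 of the 4 values shown sits. The step from compound 3 cannot be read.

The compounds shown leave open whether the hydroxy or the methyl group of compound 4 accounts for its result, as each phenyl group here differs in more than one substituent. As far as these compounds go, how an amine or a carboxylic acid on the phenyl ring would read also remains open.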